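Sulfonamide hydrazides against breast cancer cells: a fluorobenzoyl variant

A few compounds are considered here, and "the series" means these few. Any claim that something is new, unique, unknown or untested is made for them only; others in the source may bear on it.

Measured so far:
compound 1, `Cc1cccc(NNC(=O)c2ccccc2NS(=O)(=O)c2cnc(O)nc2O)c1`: > 20000 nM
compound 2, `Cc1ccccc1C(=O)NNC(=O)c1cccc(NS(=O)(=O)c2cnc(O)nc2O)c1`: 18100 nM

Both compounds were tested in a functional assay on MDA-MB-231 cells (Homo sapiens) for antiproliferative activity, read by MTT assay, with a stated time of 24 h; a higher number here means a weaker inhibitor, a lower number a stronger inhibitor. For compound 1 the result is only a limit of the assay, > 20000 nM, and not a number; this is the limit of > 20000 nM in this assay, at which 1 of the 2 values shown sits. In this assay compound 2 gives 18100 nM. For the measured compounds named here, no pair of measured compounds differs in a single place, so no measured step is available.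

Compound 3, `O=C(NNC(=O)c1ccccc1NS(=O)(=O)c1cnc(O)nc1O)c1ccc(F)cc1`, is not yet measured. It differs from compound 1 by (4-fluorophenyl)carbonyl in place of 3-methylphenyl on an amine nitrogen. With compound 1 known only as a limit, the step from compound 1 to compound 3 in this assay is expected to be small, within the usual scatter or at most a slight gain, as a step that the limit leaves unreadable from compound 1 to compound 3. Compound 3 is therefore estimated at 22000 nM, with a range from 8000 nM to 60000 nM, and a limit rather than a number is quite possible.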

Compound 3, half-maximal inhibitory concentration: > 20000 nM
Compound 3: a limit, no number; the forecaster's own chance of this, stated with the estimate: 55%; the middle value does not contradict the limit.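

The step from compound 1 to compound 3 cannot be read, since both compounds stop at the same limit of the assay and neither gives a number: the limit of > 20000 nM in this assay, at which 2 of the 3 values shown sit. The compounds shown leave open whether (4-fluorophenyl)carbonyl in place of 3-methylphenyl on an amine nitrogen changes the result in this assay at all.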